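Aryl ether variation on the hydrazide series

This account rests on a few compounds, and the source may have more. Where it says the series, first, only, none or still open, it means among the compounds named here.

Measured compounds:
- compound 1, `O=C(NNC(=O)C1CC1c1ccc(OCC(F)(F)F)cc1)c1ccncc1`: 19000 nM
- compound 2, `COc1ccc(C2CC2C(=O)NNC(=O)c2ccncc2)cc1`: a limit, > 100000 nM
- compound 3, `CCOc1ccc(C2CC2C(=O)NNC(=O)c2ccncc2)cc1`: 63000 nM

In a functional assay on U-373MG ATCC cells (Homo sapiens) for inhibition, read by MTT assay, with a stated time of 72 h (on this read-out higher numbers stand for weaker inhibition and lower numbers for stronger inhibition), compound 1 gives 19000 nM. For compound 2 the result is a limit of the assay, > 100000 nM, (the limit of > 100000 nM in this assay, at which 1 of the 3 values shown sits). Compound 3 gives 63000 nM, the highest of the two numbers reported; its nearest neighbour is compound 1, a 3.3-fold higher number from compound 1 to compound 3 (0.52 log units; beyond the scatter).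

Compound 4, `O=C(NNC(=O)C1CC1c1ccc(OC(F)(F)F)cc1)c1ccncc1`, differs from compound 3 in one place: trifluoromethyl in place of ethyl on an oxygen on an aromatic ring.

Among the compounds with values here, the steps that bear on it are those replacing trifluoromethyl on the chain carbon bound to the oxygen: a 3.3-fold higher number from compound 1 to compound 3 (0.52 log units; beyond the scatter) and an at least 5.2-fold higher number from compound 1 to compound 2 (0.72 log units; beyond the scatter). Both read as a weakening when fluorines are removed. Going from compound 3 to compound 4 puts fluorines back, so a lower number in this assay is expected, of roughly the size seen between compound 1 and compound 3. Compound 4 is therefore estimated at 20000 nM, range 7000 nM to 60000 nM, which means an expected step of a 3.2-fold lower number from compound 3 to compound 4 (0.50 log units; beyond the scatter).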

Compound 4, half-maximal inhibitory concentration: 37000 nM
Estimate against measurement, compound 4: 1.9-fold (0.27 log units) below; the range from low to high includes it.
By their numbers in this assay, from the lowest: compounds 1, 4 and 3 (each within the scatter of the next, the first and the last beyond it). At a limit, above all of these: compound 2.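

The ethoxy to trifluoromethoxy change gives a 1.7-fold lower number from compound 3 to compound 4 (0.23 log units; within the scatter), and replacing 2,2,2-trifluoroethyl with trifluoromethyl on the same oxygen gives a 1.9-fold higher number from compound 1 to compound 4 (0.29 log units; within the scatter), so compound 4 cannot be separated from either neighbour. The gap between compound 1 and compound 3 therefore does not show up as a clear step when trifluoromethyl sits directly on the oxygen, and fluorine in the group does not by itself separate compound 4 from the unfluorinated compound 3. The only step from compound 4 beyond the scatter is an at least 2.7-fold lower number from compound 2 to compound 4 (0.43 log units; beyond the scatter), and it is only a floor, since compound 2 stands at a limit: the limit of > 100000 nM in this assay, at which 1 of the 4 values shown sits.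

From the compounds shown here alone, how a longer chain such as propyl or a 3,3,3-trifluoropropyl group on this oxygen would read remains open. Also open, going by these compounds, is whether an amine or a carboxylic acid at the end of such a chain would give a number clearly lower than that of compound 1, which gives 19000 nM.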